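The source may hold more compounds than are shown below. What is called first, only, known or untested is meant among the compounds shown, and "the series" means these compounds.

Working notes on the series. Of the compounds shown here, three have numbers so far. Compound 1 `CC[C@H](C)[C@H](N)CN(C(=O)[C@@H]1C[C@H]1c1cccc(Cl)c1)c1ccc(-c2ccccc2)cc1` gives 2200 nM in a functional assay for agonist activity at G protein-coupled receptor 88 (Homo sapiens), read by HTRF and cAMP accumulation; a lower number here means that less compound is needed, a higher number that more compound is needed for the effect. For the measured compounds named here, compound 2 `CC[C@H](C)[C@H](N)CN(C(=O)[C@@H]1C[C@H]1c1cccc(C#N)c1)c1ccc(-c2ccccc2)cc1` gives 1600 nM in this assay, and the only single-point step in the set, a 1.4-fold lower number from compound 1 to compound 2 (0.14 log units; within the scatter), lies within the scatter. Compound 3 `CC(C)C[C@H](N)CN(C(=O)[C@@H]1C[C@H]1c1ccccc1)c1ccc(-c2cccs2)cc1` gives 1500 nM in this assay; its gaps to compound 2 and to compound 1 are both within the scatter, so the three numbers cannot be told apart.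

Compound 4 `CC(C)C[C@H](N)CN(C(=O)[C@@H]1C[C@H]1c1ccccc1)c1ccc(-c2cccc(F)c2)cc1` has not been measured. It differs from compound 3 by 3-fluorophenyl in place of thiophen-2-yl on an aromatic carbon. Going by the values given here, no measured step touches this part of the core: the single step measured concerns a substituent on the other aromatic ring and was within the scatter. Among the compounds with values here, compound 1 and compound 2, which carry a plain phenyl at the corresponding place while differing elsewhere from compound 3, sit within the scatter of compound 3, which gives the only indirect guide. The expected step of a 1.2-fold higher number from compound 3 to compound 4 (0.08 log units; within the scatter) is therefore none beyond the scatter. Compound 4 is expected to give 1800 nM in this assay, between 800 nM and 4000 nM.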

Compound 4, half-maximal effective concentration: 2100 nM
Compound 4: middle estimate off by 1.2-fold (0.07 log units), on the low side, within the range that was stated.
By their numbers in this assay, from the lowest: compounds 3, 2, 4 and 1 (each within the scatter of the next).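

In this assay, for the compounds shown here, the first direct reading at this place, on an aromatic carbon para to a large group, lies within the scatter (a 1.4-fold higher number from compound 3 to compound 4 (0.15 log units; within the scatter)), so thiophen-2-yl and 3-fluorophenyl cannot be told apart here. The exchange of a five-membered aromatic ring with one hetero atom for a six-membered aromatic ring of carbon only therefore leaves the number unresolved, as does the step on the other aromatic ring (a 1.4-fold lower number from compound 1 to compound 2 (0.14 log units; within the scatter)). No supporting data bear on this result.

As far as these compounds go, it remains open whether a pyridin-3-yl ring or a carboxylic acid at this place would give a step beyond the scatter. Also open, from the compounds shown here alone, is whether plain phenyl on the core of compound 3 would read differently from either group.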